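Swapping an Amide for a Benzyl Ether on the Pyrrolidine Core

The compounds below may be only part of what the source reports. "The series", "measured", "known", "first", "only" and "open" are said of these compounds alone.

Measured so far:
- compound 1 `O=C(N[C@@H]1C[C@H](C(=O)NO)N(S(=O)(=O)c2ccc(Cl)c(Cl)c2)C1)c1cccs1`: 95%
- compound 2 `O=C(N[C@H]1C[C@H](C(=O)NO)N(S(=O)(=O)c2ccc(Cl)c(Cl)c2)C1)c1cccs1`: reported as "not active" (no number reported), with no number
- compound 3 `O=C(NO)[C@H]1C[C@H](n2cc(-c3ccccc3)nn2)CN1S(=O)(=O)c1ccc(Cl)c(Cl)c1`: 91%

All three share one core and were tested in an assay on isolated protein for inhibition of matrix metalloproteinase-9 (Homo sapiens), read by fluorescence, with stated times of 5 min and 30 min, tested at 5 uM; on this read-out lower numbers stand for less inhibition and higher numbers for more inhibition at the one concentration tested (going by the name of the read-out). Compound 1 reaches 95%, while compound 2 is reported as "not active" (no number reported), so no number can be placed against it. The two differ only in the drawn configuration (the fact that compounds 1 and 2 differ only in the configuration as drawn). Compound 3, which carries a phenyl-bearing triazole in place of the amide of the other two, gives 91%.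

Compound 4 `O=C(NO)[C@H]1C[C@H](OCc2ccccc2)CN1S(=O)(=O)c1ccc(Cl)c(Cl)c1` is the next step from compound 2. The change is benzyloxy in place of ((thiophen-2-yl)carbonyl)amino on a saturated ring carbon. The donor-bearing amide leaves and an ether-linked benzyl group enters at the same saturated ring carbon.

Going by the values given here, since compound 2 has no number, no step can be computed and no direction measured. Compound 3 shows that a non-amide group at this ring carbon can still go with a high number in this assay, so a number well above what the reported verdict for compound 2 suggests is plausible, though far from certain. Compound 4 is therefore expected to give about 65%, within a range from 25% to 95%.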

Compound 4, a percentage reported as inhibition, at one concentration (the size of the read-out at that concentration, not a potency): 37%
Compound 4: middle estimate off by 28 percentage points, on the high side; the range from low to high includes it.
By their numbers in this assay, from the lowest: compound 4; then compounds 3 and 1 (each within the scatter of the next).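

Going by these compounds alone, compound 2 is reported as "not active" with no number, so the change from compound 2 to compound 4 gives no step that can be read. The compounds shown leave open how benzyloxy compares with ((thiophen-2-yl)carbonyl)amino at this ring carbon when both carry a number. Nothing given here accounts for the result of compound 4.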